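Compound 3 in the cytotoxicity series: a limit-bound step

The source may report more compounds than this note shows. Statements on the series, on what has been measured and on what is new or still open speak of the compounds shown alone.

Measured in an ADME assay on BE(2)-C cells (Homo sapiens) for cytotoxicity, read by MTT assay, with a stated time of 20 h (on this read-out lower numbers stand for higher toxicity in this test and higher numbers for lower toxicity in this test), both values being limits:
compound 1 `CN(Cc1ccccc1)C(=O)C1CCN(C(=O)c2cc3ccccc3n2Cc2ccc([N+](=O)[O-])cc2)CC1`: > 100000 nM
compound 2 `CC(=O)n1c(C(=O)N2CCC(C(=O)N(C)Cc3ccccc3)CC2)cc2ccccc21`: > 50000 nM

Compound 2 stands only at a limit, > 50000 nM, and has no number to place it. The other measured compound also offers only a limit, so the series has no measured value to anchor an estimate.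

Compound 3 `CN(Cc1ccccc1)C(=O)C1CCN(C(=O)c2cc3ccccc3n2Cc2ccncc2)CC1` is the next member. It carries (pyridin-4-yl)methyl in place of acetyl on an aromatic nitrogen, the atom next to the ring atom that bears a large group: (pyridin-4-yl)methyl in place of acetyl on an aromatic nitrogen.

Within the data shown here, the one measured step at this place is a step that the two limits leave unreadable from compound 1 to compound 2. Both its ends are limits, so it gives neither a size nor a direction.

The expectation rests mainly on compound 1, which carries 4-nitrobenzyl on that nitrogen and stays at its limit of > 100000 nM. No clear shift is therefore expected in this assay, and the report may again be only a limit. The estimated change is a number no higher from compound 2 to compound 3 (the limit leaves the size open), with no direction expected beyond the scatter. Compound 3 is expected at 50000 nM, with an estimated range of 15000 nM to 100000 nM.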

Compound 3, half-maximal cytotoxic concentration: 80300 nM
Compound 3: the middle estimate sits 1.6-fold (0.21 log units) below what was measured; low and high end bracket the measured number.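

In this assay, among these compounds, compound 3 gives 80300 nM, the only value shown that is a number and not a limit, so this position on the aromatic nitrogen now has one measured point. Going by these compounds, exchanging the 4-nitrophenyl for pyridin-4-yl on the saturated chain carbon gives an at least 1.2-fold lower number from compound 1 to compound 3 (0.09 log units; that floor lies within the scatter), so no shift beyond the scatter is established, although the true size of the step stays open. The steps that involve compound 2 cannot be read, as each has a limit at one end: the limit of > 50000 nM in this assay, at which 1 of the 3 values shown sits.

The compounds shown leave open how a chain ending in an amine or a carboxylic acid on this aromatic nitrogen would read in this assay, and whether any group at this place brings the number down clearly. They also leave open how far compound 3 truly lies from compound 1 and from compound 2, and whether the ring nitrogen of pyridin-4-yl plays any part in the number.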